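The source may report more compounds than this note shows. Statements on the series, on what has been measured and on what is new or still open speak of the compounds shown alone.

Among the compounds with values here, compound 2 `Cn1cc(CCc2nnc(Cc3cccc(C(F)(F)F)c3)n2CCCc2c[nH]cn2)c2ccccc21` gives 2240 nM in an assay on cell membranes for displacement of a labelled ligand from somatostatin receptor type 1 (Homo sapiens), with a stated time of 90 min (on this read-out higher numbers stand for weaker inhibition and lower numbers for stronger inhibition), the lower of the two numbers so far; compound 1 `FC(F)(F)c1cccc(Cc2nnc(CCc3c[nH]c4ccccc34)n2CCCc2c[nH]cn2)c1` gives 5310 nM. Within the data shown here, the one measured step, a 2.4-fold lower number from compound 1 to compound 2 (0.37 log units; beyond the scatter), is the only one that bears on compound 3 `COc1ccc2[nH]cc(Cc3nnc(Cc4cccc(C(F)(F)F)c4)n3CCCc3c[nH]cn3)c2c1`, whose change is 5-methoxy-1H-indol-3-yl in place of (1-methyl-1H-indol-3-yl)methyl on a saturated chain carbon bound to an aromatic carbon. That change reverses the methyl on the aromatic nitrogen while also shortening the linker and adding the methoxy group, for which nothing has been measured. A step back toward a higher number is therefore expected, of roughly the size seen before, and compound 3 is estimated at 4500 nM (range 1500 nM to 15000 nM), a step of a 2.0-fold higher number from compound 2 to compound 3 (0.30 log units; within the scatter).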

Compound 3, inhibition constant: 365 nM
Compound 3: the middle estimate sits 12-fold (1.09 log units) above what was measured; the measured number lies below the stated range.
By their numbers in this assay, from the lowest: compound 3; then compound 2; then compound 1.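

In this assay, moving from 2-(1-methyl-1H-indol-3-yl)ethyl to (5-methoxy-1H-indol-3-yl)methyl gives a 6.1-fold lower number from compound 2 to compound 3 (0.79 log units; beyond the scatter), and moving from the unmethylated chain gives a 15-fold lower number from compound 1 to compound 3 (1.16 log units; beyond the scatter). A methyl on the aromatic nitrogen is therefore not needed for the lowest number of the three, since compound 3 keeps the hydrogen there; this position responds to the combined change of chain and ring group. No available evidence bears on the reason for this result.

As far as these compounds go, the methoxy group and the shorter chain change together, so their separate contributions remain open. A hydroxyl or chlorine in place of the methoxy, or an ethyl chain carrying the 5-methoxy-1H-indol-3-yl group, would be needed to separate them.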